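This account rests on a few compounds, and the source may have more. Where it says the series, first, only, none or still open, it means among the compounds named here.

Measured so far in a functional assay on the whole organism for inhibition, with Rattus norvegicus as the target, at a dose of 30 mg/kg; on this read-out higher numbers stand for more inhibition at the one dose given (going by the name of the read-out) and lower numbers for less inhibition:
compound 1, `Fc1cccc(-c2nc3cccnc3o2)c1`, gives 35%;
compound 2, `Fc1ccc(-c2nc3ncccc3o2)c(F)c1`, gives 23%;
compound 3, `Clc1cccc(-c2nc3cccnc3o2)c1`, gives 8%.

The difference between the core of compound 1 and the core of compound 2 is not broken down here. Within the series, compound 2 stands second of the three numbers: compound 1 sits above it and compound 3 below it, both gaps beyond the scatter.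

One change is seen twice. From compound 1 to compound 3 it is chloro in place of fluoro on an aromatic carbon, and in this assay the step is a number 27 percentage points lower from compound 1 to compound 3 (beyond the scatter).

Compound 4, `Fc1cc(Cl)ccc1-c1nc2ncccc2o1`, has not yet been measured. It differs from compound 2 by chloro in place of fluoro on an aromatic carbon. This is the same kind of change as from compound 1 to compound 3, not the same: in compound 3 the site is meta to a group of 9 heavy atoms, whereas in compound 4 it is meta to a fluoro group (1 heavy atom) and para to a group of 9 heavy atoms.

The expectation for compound 4 rests on the one shown instance: because a number 27 percentage points lower from compound 1 to compound 3 (beyond the scatter) was a drop, a drop of similar kind is expected here too, set beside the earlier one as a number 15 percentage points lower from compound 2 to compound 4 (beyond the scatter). With compound 2 already at 23%, the room downward is limited, so the expected step is smaller. Compound 4 is estimated at 8%, with a range from -5% to 22%.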

Compound 4, a percentage reported as inhibition, in the whole organism at one dose (the size of the read-out at that dose, not a potency): 19%
The estimate for compound 4 lay 11 percentage points below the measured number; measured number inside the range.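

In this assay, chloro in place of fluoro on an aromatic carbon, here meta to a fluoro group and para to a group of 9 heavy atoms, gives a number 4 percentage points lower from compound 2 to compound 4 (within the scatter). The change therefore does not carry over at one size from the core of compound 1 to the core of compound 2: the same change on two cores in this assay, a number 27 percentage points lower (beyond the scatter) from compound 1 to compound 3 and a number 4 percentage points lower (within the scatter) from compound 2 to compound 4, 23 percentage points apart, beyond the scatter of two such steps

This does not show which difference sets the two steps apart, as the two pairs differ at once in the core, in the place of the exchanged halogen and in the second fluoro group of compound 2 and compound 4, and two instances give no rule for a third core.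

Open, on these data alone, is how this assay responds to a group other than fluoro or chloro on the six-membered aromatic ring of carbon only, such as methoxy, an amine, a carboxylic acid or a longer chain. Also open is whether the same halogen exchange on the core of compound 2, made at the site it occupies in compound 3, would follow the larger step or the smaller one, and the single-dose read-out gives no potency for any of these compounds.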